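Methyl in Place of Bromo on a Shared Fused Core

The source may hold more compounds than are shown below. What is called first, only, known or untested is meant among the compounds shown, and "the series" means these compounds.

Measured compounds:
compound 1, `O=C(CCC(=O)c1ccccc1)Nc1nc2ccc(Cl)cc2s1`, 300 mg/kg
compound 2, `O=C(CCC(=O)c1ccccc1)Nc1nc2cc(Cl)c(F)cc2s1`, 300 mg/kg
compound 3, `O=C(Nc1nc2ccc(Br)cc2s1)c1ccccc1C(=O)c1ccccc1`, 300 mg/kg

Of the compounds shown here, three have so far been tested in a functional assay on the whole organism with Mus musculus as the target, in the maximal electroshock model, with a stated time of 0.5 h; on this read-out lower numbers stand for an effect already at smaller amounts and higher numbers for an effect only at larger amounts of compound. On this read-out compound 3 stands level with compound 1 and with compound 2 at the digits shown; the gaps to both lie within the scatter of repeated measurements, so no order among the three can be read from these numbers.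

The next compound, compound 4, has the structure `Cc1ccc2nc(NC(=O)c3ccccc3C(=O)c3ccccc3)sc2c1` and awaits testing in this assay. Its difference from compound 3 is a single exchange: methyl in place of bromo on an aromatic carbon. One heavy atom leaves and one heavy atom enters, with no ring, no hydrogen-bond donor and no hydrogen-bond acceptor gained or lost.

For the measured compounds named here, no step between two measured compounds has been recorded in this set, so there is no measured precedent for what such an exchange does here. Given that the three measured compounds all sit at the same level, the expectation for compound 4 is no change beyond the scatter, which as a step is no change at the digits printed from compound 3 to compound 4 (within the scatter). The estimated minimum effective dose of compound 4 is therefore 300 mg/kg, with a likely range from 150 mg/kg to 600 mg/kg.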

Compound 4, minimum effective dose: 300 mg/kg
Beside the measured number, compound 4's estimate shows no gap at the digits printed; the measured number falls inside the stated range.
By their numbers in this assay, from the lowest: compounds 1, 2, 3 and 4 (each within the scatter of the next).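

For the compounds shown here, there is no change at the digits printed from compound 3 to compound 4 (within the scatter) when methyl takes the place of bromo on an aromatic carbon of the shared core, and this is the first exchange at a single place to be read in this assay. The earlier compounds shown here could not show this, since no two of them differed in one place only: at this carbon, a bromine can give way to a carbon with no change in the read-out beyond the scatter. No evidence is at hand on what lies behind this result.

This single pair says nothing yet about other groups, so an amine or a carboxylic acid on the same carbon could still read differently. It also leaves open whether the same exchange would read alike on a compound with the longer chain of compound 1.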